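Pyridyl for dimethylphenyl on the shared core

The compounds below may be only part of what the source reports. "The series", "measured", "known", "first", "only" and "open" are said of these compounds alone.

Of the compounds shown here, two have been measured in a functional assay on HL-60 cells (Homo sapiens) for activation, read by flow cytometry, with a stated time of 4 days; a lower number here means that less compound is needed, a higher number that more compound is needed for the effect. Compound 1 `COc1ccc(-n2cnc3cnc(Oc4cccc(NC(C)=O)c4)cc32)cc1OC` returns only a limit, > 30000 nM, and gives no number. Within the data shown here, compound 2 `Cc1cccc(C)c1-c1cc2c(cn1)ncn2-c1ccc(OC(F)F)cc1` gives 980 nM in this assay, which is the only number so far; the other value sits at the limit of > 30000 nM in this assay, at which 1 of the 2 values shown sits. The next compound, compound 3 `Cc1nc(F)ccc1-c1cc2c(cn1)ncn2-c1ccc(OC(F)F)cc1`, is not yet measured in this assay.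

The change from compound 2 to compound 3 is 6-fluoro-2-methylpyridin-3-yl in place of 2,6-dimethylphenyl on an aromatic carbon. The two groups match in size, and one methyl of the 2,6-dimethylphenyl is exchanged for fluorine while the ring gains one nitrogen. Among the measured compounds shown here, no measured pair shows such a change, so the expected step of a 1.2-fold higher number from compound 2 to compound 3 (0.09 log units; within the scatter) is small and not beyond the usual scatter in either direction. Compound 3 is therefore estimated at 1200 nM in this assay, with a range of 400 nM to 4000 nM.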

Compound 3, half-maximal effective concentration: 2000 nM
Compound 3: middle estimate off by 1.7-fold (0.22 log units), on the low side; low and high end bracket the measured number.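

In this assay, among these compounds, the first readable step is a 2.0-fold higher number from compound 2 to compound 3 (0.31 log units; beyond the scatter), with 6-fluoro-2-methylpyridin-3-yl in place of 2,6-dimethylphenyl on the aromatic carbon next to the ring nitrogen. This position therefore responds to the exchange of one aromatic ring for another, though modestly, and compound 3 still gives a number rather than a limit. Among the compounds shown here, nothing measured so far accounts for this step, which rests on a single pair.

Going by these compounds, the exchange combines a ring nitrogen with fluorine in place of one methyl, so the share of each in the step stays open. Also open, on these data alone, is how this position would read with a ring bearing an amine or a carboxylic acid.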